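This account rests on a few compounds, and the source may have more. Where it says the series, first, only, none or still open, it means among the compounds named here.

Of the compounds shown here, two have so far been measured in an assay on isolated protein for inhibition of Amine oxidase [flavin-containing] A (Homo sapiens), read by fluorescence and spectrophotometry; on this read-out higher numbers stand for weaker inhibition and lower numbers for stronger inhibition. Compound 1, `Cc1cccc(C)c1[Se]CC(C)N`, gives 1680 nM in this assay. Compound 2, `CC(N)CSc1cccc(Br)c1`, gives 7820 nM in this assay. Of these two numbers, compound 1 has the lower one, and the gap between them lies beyond the usual scatter of repeated measurements, so compound 1 is the stronger inhibitor of the pair.

Compound 3, `Cc1ccccc1[Se]CC(C)N`, has not yet been measured. It differs from compound 1 in one place: hydrogen in place of methyl on an aromatic carbon. Among the measured compounds shown here, no pair of measured compounds shares this change, so its effect on inhibition is not known from the numbers in hand. A single methyl is a small piece of the whole molecule, and the step from compound 1 to compound 3 is expected to be modest, leaning toward weaker inhibition, and it may not reach beyond the scatter. Compound 3 is expected to give about 2500 nM in this assay, within a range from 800 nM to 8000 nM. This expectation amounts to a 1.5-fold higher number from compound 1 to compound 3 (0.17 log units; within the scatter).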

Compound 3, half-maximal inhibitory concentration: 5170 nM
Compound 3: the middle estimate sits 2.1-fold (0.32 log units) below what was measured, within the range that was stated.
By their numbers in this assay, from the lowest: compound 1; then compounds 3 and 2 (each within the scatter of the next).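

The methyl on this aromatic carbon, ortho to a group of 5 heavy atoms and meta to a methyl group, makes a measurable difference: in this assay, replacing it with hydrogen gives a 3.1-fold higher number from compound 1 to compound 3 (0.49 log units; beyond the scatter). Among the compounds shown here, this is the first comparison here between two compounds that differ in only one place, so the effect of this change can now be read directly rather than inferred from compounds that differ in several ways, and the form carrying the methyl is the stronger inhibitor of the pair. No measurement available here bears on why this one carbon atom changes inhibition by this much.

With only methyl and hydrogen shown at this position, it remains open whether a larger or different group, such as ethyl, methoxy or a chlorine atom, would give stronger or weaker inhibition than methyl. Going by these compounds, it is also open whether the same change would have a similar effect in a compound built like compound 2, whose ring carries a bromine atom and whose side chain is attached through sulfur.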